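Removing the Methyl from the Core Nitrogen

A few compounds are considered here, and "the series" means these few. Any claim that something is new, unique, unknown or untested is made for them only; others in the source may bear on it.

Compound 1 `CC(=O)Nc1ccc(-c2nc3cc(C(F)(F)F)ccc3n2C)cc1` was tested in an ADME assay on BHK cells (Mesocricetus auratus) for cytotoxicity, read by MTT assay, with a stated time of 96 h; a lower number here means that less compound is tolerated, a higher number that more compound is tolerated. In this assay compound 1 reaches only the limit of the assay, > 100000 nM, and no number. Compound 2 `Cn1c(-c2ccc(NC(=O)CN3CCN(c4ccccc4)CC3)cc2)nc2cc(C(F)(F)F)ccc21` gives 100000 nM in this assay, and compound 2 thus holds the only number shown. The step of a number no higher from compound 1 to compound 2 (the limit leaves the size open) leaves its size open, since one of its two values is the limit (the limit of > 100000 nM in this assay, at which 1 of the 2 values shown sits).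

Compound 3 `O=C(CN1CCN(c2ccccc2)CC1)Nc1ccc(-c2nc3cc(C(F)(F)F)ccc3[nH]2)cc1` differs from compound 2 by hydrogen in place of methyl on an aromatic nitrogen. Going by the values given here, the only measured step concerns the chain and not the aromatic nitrogen, so no measured step bears on this change. Compound 3 is therefore expected to tolerate about as much as compound 2, with an estimated step of no change at the digits printed from compound 2 to compound 3 (within the scatter) not beyond the scatter. For compound 3 the estimate in this assay is 100000 nM, within a range from 50000 nM to 200000 nM.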

Compound 3, half-maximal cytotoxic concentration: > 100000 nM
Compound 3: a limit, no number (the forecaster's own chance of this, stated with the estimate: 50%); the middle value sits exactly at the limit.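

In this assay compound 3 gives > 100000 nM, a limit of the assay and not a number. The earlier compounds shown here both carry methyl on the aromatic nitrogen, and this result shows that hydrogen can stand there with no lower number, as the step reads a number no lower from compound 2 to compound 3 (the limit leaves the size open), though its size cannot be read. The limit also narrows what this series can show in this read-out: the limit of > 100000 nM in this assay, at which 2 of the 3 values shown sit.

From the compounds shown here alone, how a larger group on this aromatic nitrogen, such as ethyl or a longer chain bearing an amine, would read in this assay stays open. Going by these compounds, whether the hydrogen in compound 3 matters at all in this read-out also stays open, since the values shown do not say how far compound 3 lies beyond its limit.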